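Benzoyl for Chlorobenzyl on a Sigma-1 Ligand Series

This account rests on a few compounds, and the source may have more. Where it says the series, first, only, none or still open, it means among the compounds named here.

Measured compounds:
compound 1 `Fc1ccc(C(SCCNC2CCN(Cc3ccc(Cl)cc3)CC2)c2ccc(F)cc2)cc1`: 45.5 nM
compound 2 `[O-][S+](CCNC1CCN(CC(O)Cc2ccccc2)CC1)C(c1ccc(F)cc1)c1ccc(F)cc1`: 351 nM

In an assay on membranes from Cortex for displacement of a labelled ligand from Sigma non-opioid intracellular receptor 1 (Cavia porcellus), read by scintillation counting, with a stated time of 120 min (a lower number here means a stronger inhibitor, a higher number a weaker inhibitor), compound 1 gives the lower of the two numbers, and compound 2 gives a number that lies well beyond the scatter above it. Compound 3 `O=C(c1ccccc1)N1CCC(NCCSC(c2ccc(F)cc2)c2ccc(F)cc2)CC1` is not yet measured. It differs from compound 1 in one place: benzoyl in place of 4-chlorobenzyl on an amine nitrogen in a ring. Within the data shown here, no step between measured compounds covers this change, so expectation rests on compound 1 alone. A weakening step of moderate size is expected, a 4.4-fold higher number from compound 1 to compound 3 (0.64 log units; beyond the scatter), since the change alters the amine nitrogen in the ring that compound 1 carries. Compound 3 is therefore estimated at 200 nM, within 50 nM to 800 nM.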

Compound 3, inhibition constant: 2.03 nM
Beside the measured number, compound 3's estimate is 99-fold (1.99 log units) above it, outside the stated range (below it).
By their numbers in this assay, from the lowest: compound 3; then compound 1; then compound 2.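

In this assay, benzoyl in place of 4-chlorobenzyl on the amine nitrogen in the ring gives a 22-fold lower number from compound 1 to compound 3 (1.35 log units; beyond the scatter), a large strengthening. Among these compounds, this shows that the position accepts a carbonyl attached directly to that nitrogen and that the group there can shift the number strongly, which the earlier compounds, joined by no single-place step, could not show. No measurement shown bears on why the step is this large. As far as these compounds go, it remains open whether the gain follows the carbonyl or the loss of chlorine; plain benzyl or 4-chlorobenzoyl on that nitrogen would separate the two.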